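A few compounds are considered here, and "the series" means these few. Any claim that something is new, unique, unknown or untested is made for them only; others in the source may bear on it.

Compound 1 `CC(C)Nc1nc(Cl)nc(N[C@@H](C)c2ccccc2)n1`: 11000 nM
Compound 2 `CC(C)N(c1nc(Cl)nc(N[C@H](C)c2ccccc2)n1)C(C)C`: 6610 nM
Compound 3 `CCCN(C)c1nc(Cl)nc(N[C@H](C)c2ccccc2)n1`: 9770 nM

In an ADME assay on the whole organism for inhibition, with Echinochloa crus-galli var. formosensis as the target, with a stated time of 4 days (on this read-out higher numbers stand for weaker inhibition and lower numbers for stronger inhibition), compound 3 stands second highest of these three numbers. Its gap to compound 1 is within the scatter, and the step of a 1.5-fold higher number from compound 2 to compound 3 (0.17 log units; within the scatter) is also within the scatter, so the three measured compounds are not separated by this read-out.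

Compound 4 `CCN(CC)c1nc(Cl)nc(N[C@H](C)c2ccccc2)n1` differs from compound 3 in one place: diethylamino in place of methyl(propyl)amino on an aromatic carbon. For the measured compounds named here, the only measured step that bears on this change is a 1.5-fold higher number from compound 2 to compound 3 (0.17 log units; within the scatter), where one alkylamino group replaced another at the same place without a shift beyond the scatter. On that basis no step beyond the scatter is expected here; the estimated step is a 1.1-fold lower number from compound 3 to compound 4 (0.04 log units; within the scatter). Compound 4 is therefore estimated at 9000 nM, with a range from 4000 nM to 20000 nM.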

Compound 4, half-maximal inhibitory concentration: 24000 nM
Beside the measured number, compound 4's estimate is 2.7-fold (0.43 log units) below it; the measured number lies above the stated range.
By their numbers in this assay, from the lowest: compounds 2, 3 and 1 (each within the scatter of the next); then compound 4.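

At the amino group on the shared core, diethylamino in place of methyl(propyl)amino keeps the same atoms, joined differently, yet in this assay it gives a 2.5-fold higher number from compound 3 to compound 4 (0.39 log units; beyond the scatter). Diethylamino in place of diisopropylamino gives a 3.6-fold higher number from compound 2 to compound 4 (0.56 log units; beyond the scatter), so this position does respond to how its alkyl groups are arranged, which the earlier step within the scatter could not show. Nothing available explains why these groups differ. Still open, from the compounds shown here alone, is how a ring amine such as piperidine, or a longer chain such as dibutylamino, would read at this position.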